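The source may report more compounds than this note shows. Statements on the series, on what has been measured and on what is new or still open speak of the compounds shown alone.

In an ADME assay on MT4 cells (Homo sapiens) for cytotoxicity, read by MTT assay, with a stated time of 5 days (a higher number here means that more compound is tolerated, a lower number that less compound is tolerated), compound 3 (`Cc1cnc(Nc2ccc(C#N)cc2)nc1OCC(=O)Nc1ccccc1F`) gives > 331000 nM, which is a limit and not a number. Compound 2 (`Cc1cnc(Nc2ccc(C#N)cc2)nc1OCC(=O)Nc1ccc(F)cc1`) gives > 331000 nM, also a limit. Going by the values given here, compound 3 therefore has no number of its own, and neither do the other compounds tested so far.

Compound 4 (`Cc1cnc(Nc2ccc(C#N)cc2)nc1OCC(=O)Nc1cccc(Cl)c1`) differs from compound 3 in one place, with 3-chlorophenyl in place of 2-fluorophenyl on an amide-type nitrogen. Among the compounds with values here, the only measured step at this nitrogen is a step that the two limits leave unreadable from compound 2 to compound 3, so it offers no size to carry over. The nearest guide is compound 1 (`N#Cc1ccc(Nc2nccc(OCC(=O)Nc3cccc(Cl)c3)n2)cc1`), which carries the same 3-chlorophenyl on its amide-type nitrogen and gives > 329000 nM, again a limit.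

On that basis, compound 4 is expected to reach a limit as well, with no change beyond the scatter in either direction. The expected step is an at least 1.0-fold lower number from compound 3 to compound 4 (0.01 log units; that floor lies within the scatter). The estimated value for compound 4 is 317000 nM, with an expected range from 150000 nM to 340000 nM.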

Compound 4, half-maximal cytotoxic concentration: 144000 nM
Estimate against measurement, compound 4: 2.2-fold (0.34 log units) above; the measured number lies below the stated range.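

In this assay, the group on the amide-type nitrogen now has a readable effect: 3-chlorophenyl in place of 2-fluorophenyl gives an at least 2.2-fold lower number from compound 3 to compound 4 (0.36 log units; beyond the scatter), and 3-chlorophenyl in place of 4-fluorophenyl gives an at least 2.2-fold lower number from compound 2 to compound 4 (0.36 log units; beyond the scatter). With the 3-chlorophenyl kept, methyl in place of hydrogen on an aromatic carbon gives an at least 2.2-fold lower number from compound 1 to compound 4 (0.35 log units; beyond the scatter), so among these compounds the lower number appears only with the 3-chlorophenyl and the methyl together. Compound 2 and compound 3 carry the methyl without the 3-chlorophenyl and stay at a limit: the limit of > 331000 nM in this assay, at which 2 of the 4 values shown sit.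

The steps that start from a limit give only a floor, and the step between the two fluorophenyl compounds cannot be read. Still open, from the compounds shown here alone, is how a 3-bromophenyl or 4-chlorophenyl on that nitrogen, or an ethyl in place of the methyl, would read.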